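Methoxy in place of hydrogen on the shared quinol core

This account rests on a few compounds, and the source may have more. Where it says the series, first, only, none or still open, it means among the compounds named here.

Among the measured compounds shown here, compound 1, `COC1=C[C@H](O)[C@H](C/C=C(\C)CC/C=C(\C)CCC=C(C)C)[C@@H](C)C1=O`, is the only member of this small set with a measured number: in a functional assay on A549 cells (Homo sapiens) for inhibition, read by sulforhodamine B assay, with a stated time of 48 h (a higher number here means a weaker inhibitor of growth, a lower number a stronger inhibitor of growth), compound 1 gives 16400 nM. Compound 2, `COC1=CC(=O)C(C/C=C(\C)CC/C=C(\C)CCC=C(C)C)=C(C)C1=O`, returns a limit of the assay, > 30000 nM, and no number. Compound 3, `COC1=C(OC)[C@H](OC(C)=O)[C@H](C/C=C(\C)CC/C=C(\C)C[C@H](O)/C=C(\C)C(=O)O)[C@@H](C)C1=O`, likewise returns only a limit, > 30000 nM. Compound 1 therefore stands alone with a number, while the other two values sit at the limit of > 30000 nM in this assay, at which 2 of the 3 values shown sit. For the measured compounds named here, no pair of measured compounds differs in a single place, so no measured step within the set can be read.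

The next compound, compound 4, `COC1=C(OC)[C@H](O)[C@H](C/C=C(\C)CC/C=C(\C)CCC=C(C)C)[C@@H](C)C1=O`, differs from compound 1 by methoxy in place of hydrogen on a double-bonded ring carbon. Going by the values given here, with no measured step of this kind to lean on, the change from compound 1 to compound 4 is expected to be small, at most a modest weakening of growth inhibition, possibly none beyond the scatter: the expected step is a 1.3-fold higher number from compound 1 to compound 4 (0.13 log units; within the scatter). Compound 4 is thus estimated at 22000 nM in this assay, within a range from 8000 nM to 50000 nM.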

Compound 4, concentration for 50% growth inhibition: 5700 nM
The estimate for compound 4 lay 3.9-fold (0.59 log units) above the measured number, outside the stated range (below it).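

Methoxy in place of hydrogen on a double-bonded ring carbon gives a 2.9-fold lower number from compound 1 to compound 4 (0.46 log units; beyond the scatter) in this assay, so this position of the shared core responds to substitution. Among the compounds shown here, this is the first step that can be read, and its direction is toward stronger growth inhibition rather than the small weakening or absence of change that the earlier compounds left possible. The core of compound 1 therefore accepts a group of this size at this carbon with a gain in this cell assay, though one replacement at one position shows no trend.

On these data alone, whether an ethoxy group, a chlorine atom or an amine on the same carbon would lower the number further, or raise it, remains open. Steps involving compound 2 or compound 3 cannot be read: the limit of > 30000 nM in this assay, at which 2 of the 4 values shown sit.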